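Working notes: replacing the carbamoyl on compound 3

The compounds below may be only part of what the source reports. "The series", "measured", "known", "first", "only" and "open" are said of these compounds alone.

Measured so far in an ADME assay on microsomes from liver (Rattus norvegicus) for metabolic stability, using NADPH, with a stated time of 10 min; on this read-out higher numbers stand for a more stable compound and lower numbers for a less stable compound

- compound 1 `NCCCCN(C[C@@H]1Cc2cccnc2CN1)[C@H]1CCCc2cccnc21` gives 37%
- compound 2 `NCCCCN(C[C@@H]1Cc2nccnc2CN1)[C@H]1CCCc2cccnc21` gives 67%
- compound 3 `NC(=O)NCCCCN(C[C@H]1Cc2ncccc2CN1)[C@H]1CCCc2cccnc21` gives 1%

Compound 3 stands lowest of the three numbers, beyond the scatter from both compound 1 and compound 2. Compound 4 `c1cnc2c(c1)CN[C@@H](CN(CCCCNC1CCOCC1)[C@H]1CCCc3cccnc31)C2` has not yet been measured. Its change from compound 3 is oxan-4-yl in place of carbamoyl on an amine nitrogen with oxan-4-yl in place of carbamoyl on an amine nitrogen.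

Among the compounds with values here, no measured pair differs in one place, so no direct step is available for this change. Compound 1 and compound 2 differ from compound 3 in more than one place, and their numbers give only a rough sense of the range the series can reach. The expected direction is upward, and it rests on compound 3 at 1% having little room left beneath it. The size is far less certain, and a result close to compound 3 would not be surprising. An upward move beyond the scatter is expected, with the estimated step of a number 14 percentage points higher from compound 3 to compound 4 (beyond the scatter) in this assay as the working figure. The estimated value for compound 4 is 15% (expected range 2% to 45%).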

Compound 4, percent of the compound remaining: 49%
Estimate against measurement, compound 4: 34 percentage points below; measured number above the stated range.
By their numbers in this assay, from the lowest: compound 3; then compound 1; then compound 4; then compound 2.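

In this assay, oxan-4-yl in place of carbamoyl on an amine nitrogen gives a number 48 percentage points higher from compound 3 to compound 4 (beyond the scatter), and this is the only step shown between compounds that differ in one place. It shows that this read-out responds strongly to the group on this nitrogen alone, with the rest of the structure held constant, so the very low number of compound 3 does not extend to every compound with this core and chain. The change removes a ureido group with its hydrogen-bond donor and brings in a six-membered non-aromatic ring with no hydrogen-bond donors, but nothing available explains the step.

A single step cannot separate the loss of carbamoyl from the gain of oxan-4-yl, nor show whether the ring oxygen of oxan-4-yl matters. Acetyl on the same nitrogen would test the first question, cyclohexyl the second, and the free primary amine would give a direct reference point for both groups on this core.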